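Chloro to bromo: expected paw edema inhibition for compound 3

This account rests on a few compounds, and the source may have more. Where it says the series, first, only, none or still open, it means among the compounds named here.

In a functional assay on the whole organism (strain albino) for inhibition, with Rattus norvegicus as the target, read by paw edema, with stated times of 30 min and 3 h, at a dose of 5 mg/kg by the oral route (a higher number here means more inhibition at the dose given (going by the name of the read-out), a lower number less inhibition), compound 2 `CCOC(=O)Cc1n[nH]c(NC(=O)c2ccc(Cl)cc2)n1` gives 58.5%. Among the measured compounds shown here, the one other number comes from compound 1 `CCOC(=O)Cc1n[nH]c(NC(=O)c2ccccc2)n1`, which gives 55.3%; the step of a number 3.2 percentage points higher from compound 1 to compound 2 (within the scatter) is within the scatter, so the two stand together. Compound 3 `CCOC(=O)Cc1n[nH]c(NC(=O)c2ccc(Br)cc2)n1` is not yet measured and differs from compound 2 by bromo in place of chloro on an aromatic carbon. For the measured compounds named here, no measured step exchanges one halogen for another; the only step available, hydrogen to chloro, stayed within the scatter. The step of no change at the digits printed from compound 2 to compound 3 (within the scatter) is therefore expected to stay within the scatter, with no direction favoured. Compound 3 is estimated at 58.5%, with a range from 48% to 69%.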

Compound 3, a percentage reported as inhibition, in the whole organism at one dose (the size of the read-out at that dose, not a potency): 58.8%
Beside the measured number, compound 3's estimate is 0.3 percentage points below it, within the range that was stated.
By their numbers in this assay, from the lowest: compounds 1, 2 and 3 (each within the scatter of the next).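

In this assay the exchange of one halogen for the other gives a number 0.3 percentage points higher from compound 2 to compound 3 (within the scatter) and the full change from hydrogen to bromo gives a number 3.5 percentage points higher from compound 1 to compound 3 (within the scatter) on the same aromatic carbon. At this place, para to a large group, hydrogen, chloro and bromo therefore stand together, and the second halogen separates from neither of the other two. No available data bear on why these three stand together.

Going by these compounds, whether an amine or a carboxylic acid at this place would separate from hydrogen remains open. Also open, on these data alone, is how a longer chain in place of the ethyl ester would read.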